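Bromo for amino on a benzimidazole-like shared core

The source may hold more compounds than are shown below. What is called first, only, known or untested is meant among the compounds shown, and "the series" means these compounds.

Compound 1 `CN(C)c1nc2cc(Cl)c(Cl)cc2n1COCCO` gives in a functional assay on KB cells (Homo sapiens) for inhibition (on this read-out higher numbers stand for weaker inhibition and lower numbers for stronger inhibition), only the assay limit > 100000 nM.
Compound 2 `OCCOCn1c(SCc2ccccc2)nc2c(Cl)cc(Cl)cc21` gives in this assay only the assay limit > 100000 nM.
Compound 3 `Nc1nc2c(Cl)c(Cl)ccc2n1COCCO` gives in this assay only the assay limit > 100000 nM.

None of the three measured compounds has a number in this assay; each sits at the limit. Compound 3 therefore stands exactly where the other two stand, at the limit of > 100000 nM in this assay, at which 3 of the 3 values shown sit, and nothing separates it from them. For the measured compounds named here, no step between measured compounds can be read off, as every value is a limit and not a number.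

Compound 4 `OCCOCn1c(Br)nc2c(Cl)c(Cl)ccc21` differs from compound 3 in one place: bromo in place of amino on an aromatic carbon of the five-membered aromatic ring with two nitrogen atoms, between the two ring nitrogen atoms, next to the ring atom that bears the (2-hydroxyethoxy)methyl group. The shared core, the two chlorines and the side chain are kept.

Going by the values given here, with no measured step to lean on and compound 3 at the limit, the step to compound 4 is expected to be a number no higher from compound 3 to compound 4 (the limit leaves the size open), none beyond the usual scatter. Compound 4 is estimated at 100000 nM in this assay, within 30000 nM to 300000 nM, and most likely reported again only as a limit.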

Compound 4, half-maximal inhibitory concentration: > 100000 nM
Compound 4 ended at the assay's limit (the forecaster's own chance of this, stated with the estimate: 85%); the middle value sits exactly at the limit.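

Compound 3 and compound 4 both sit at a limit and not at a number, so no step can be read between them for bromo in place of amino on an aromatic carbon: the limit of > 100000 nM in this assay, at which 4 of the 4 values shown sit.

The compounds shown leave open whether any change to the shared core would give a measured number in this assay.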